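The source may report more compounds than this note shows. Statements on the series, on what has been measured and on what is new or still open speak of the compounds shown alone.

In a functional assay on HL-60 cells (Homo sapiens) for cytotoxicity, read by WST assay, with a stated time of 48 h (a lower number here means that less compound is needed, a higher number that more compound is needed for the effect), compound 1 (`O=C1OC[C@H](Cc2ccccc2)[C@H]1Cc1ccccc1`) gives 77000 nM, compound 2 (`O=C1OC[C@H](Cc2ccccc2)[C@H]1Cc1ccc(O)cc1`) gives 88000 nM and compound 3 (`COCOc1ccc(C[C@H]2C(=O)OC[C@@H]2Cc2ccccc2)cc1`) gives 71000 nM. Compound 3 therefore stands level with the other two. Compound 4 (`CCCCOc1ccc(C[C@H]2C(=O)OC[C@@H]2Cc2ccccc2)cc1`) differs from it by propyl in place of methoxy on a saturated chain carbon bound to an oxygen on an aromatic ring, with propyl in place of methoxy on a saturated chain carbon bound to an oxygen on an aromatic ring. Within the data shown here, the steps that bear on this change are small, namely a 1.1-fold higher number from compound 1 to compound 2 (0.06 log units; within the scatter), a 1.1-fold lower number from compound 1 to compound 3 (0.04 log units; within the scatter) and a 1.2-fold lower number from compound 2 to compound 3 (0.09 log units; within the scatter). None of them tests a butoxy group, but on this evidence no change beyond the scatter is expected in this assay. The expected step is a 1.1-fold lower number from compound 3 to compound 4 (0.04 log units; within the scatter). The estimate for compound 4 is 65000 nM, within an expected range from 28000 nM to 120000 nM.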

Compound 4, half-maximal effective concentration: 23000 nM
Beside the measured number, compound 4's estimate is 2.8-fold (0.45 log units) above it; measured number outside the range, below it.
By their numbers in this assay, from the lowest: compound 4; then compounds 3, 1 and 2 (each within the scatter of the next).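

In this assay only the butoxy group moves the number beyond the scatter at this position (compared with the methoxymethoxy group: a 3.1-fold lower number from compound 3 to compound 4 (0.49 log units; beyond the scatter); with the hydroxy group: a 3.8-fold lower number from compound 2 to compound 4 (0.58 log units; beyond the scatter); with hydrogen: a 3.3-fold lower number from compound 1 to compound 4 (0.52 log units; beyond the scatter)). All three steps are modest, but they show that this position is not indifferent to its substituent, as compounds 1, 2 and 3 alone had suggested. Swapping methoxy for propyl on the saturated chain carbon is enough to separate compound 4 from compound 3. Nothing given here accounts for this shift. As far as these compounds go, it remains open whether a longer chain, such as hexyloxy, would lower the number further, or whether a shorter ethoxy group would already do so. From the compounds shown here alone, an amine at the end of the chain is equally open.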